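Methyl on the Phenolic Oxygen: Compound 1 to Compound 3

This account rests on a few compounds, and the source may have more. Where it says the series, first, only, none or still open, it means among the compounds named here.

compound 1 `CS(=O)(=O)Nc1ccc(O)c2c1CCCC2c1c[nH]cn1`: 34%
compound 2 `CS(=O)(=O)Nc1cccc2c1CCC=C2c1c[nH]cn1`: 57%; 23% (2 entries)

Going by the values given here, in a functional assay on Urethra with Alpha-1A adrenergic receptor (Oryctolagus cuniculus) as the target (a higher number here means a larger maximal response, a lower number a smaller maximal response), compound 1 gives 34%, the only single number in this set. Compound 2 has two entries, (the several entries of compound 2 in this assay, 57%; 23% (2 entries)), and they lie further apart than the usual scatter; the value of compound 1 falls between them. Compound 3 `COc1ccc(NS(C)(=O)=O)c2c1C(c1c[nH]cn1)CCC2` differs from compound 1 by methyl in place of hydrogen on an oxygen on an aromatic ring. Among the compounds with values here, no measured pair shows this change, so no step size is known from the data. A change no larger than the scatter is expected in this assay, in no particular direction. Compound 3 is therefore estimated at 32%, with a range from 12% to 58%. This expectation means a step of a number 2 percentage points lower from compound 1 to compound 3 (within the scatter).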

Compound 3, largest response reached (reported as efficacy), in percent of the reference or control that the assay uses: 57%
Compound 3: middle estimate off by 25 percentage points, on the low side; low and high end bracket the measured number.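

In this assay, going by these compounds alone, methyl in place of hydrogen on an oxygen on an aromatic ring is the first single change that can be read, and the maximal response comes out a number 23 percentage points higher from compound 1 to compound 3 (beyond the scatter). Within the data shown here, this oxygen is therefore a place where the response can move with the group it carries, though only this one pair shows it. Caution remains, as entries for a single compound in this assay can themselves lie far apart: the several entries of compound 2 in this assay, 57%; 23% (2 entries)

Going by these compounds, whether a longer chain on the oxygen, such as ethoxy, would carry the response further stays open. So does the effect of an amine or a fluorine in place of the hydroxy.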